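The source may hold more compounds than are shown below. What is called first, only, known or untested is meant among the compounds shown, and "the series" means these compounds.

Compound 1 `COc1ccc(-c2cc3c(N)cccc3c(=O)[nH]2)cc1` and compound 2 `Nc1cccc2c(=O)[nH]c(-c3cccs3)cc12` have the same core and differ in the group attached to it. In a physicochemical assay for solubility (a lower number here means a less soluble compound, a higher number a more soluble compound), compound 1 gives > 30000000 nM, which is a limit and not a number. Compound 2 gives > 30000000 nM, and this too is a limit and not a number, so compound 2 has no exact value to build on.

Compound 3 `CC(C)Cc1cc2c(N)cccc2c(=O)[nH]1` carries isobutyl in place of thiophen-2-yl on an aromatic carbon, next to the ring nitrogen (isobutyl in place of thiophen-2-yl on an aromatic carbon). Among the compounds with values here, no measured pair shows the size of such a change. In this assay, the expectation is therefore no step beyond the scatter, resting on (the limit of > 30000000 nM in this assay, at which 2 of the 2 values shown sit), and a further report of only a limit is likely. The expected change is a number no higher from compound 2 to compound 3 (the limit leaves the size open). For compound 3, the estimated value is 30000000 nM, within an expected range of 12000000 nM to 60000000 nM.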

Compound 3, solubility: > 30000000 nM
Compound 3 gave a limit, no number; the forecaster's own chance of this, stated with the estimate: 85%; the middle value sits exactly at the limit.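

Within the data shown here, compound 2 and compound 3 each give only a limit in this assay, not a number, so no step between them can be read. The compounds shown leave open the actual solubility of each, and whether isobutyl in place of thiophen-2-yl changes it at all.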